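A few compounds are considered here, and "the series" means these few. Any claim that something is new, unique, unknown or untested is made for them only; others in the source may bear on it.

Measured so far in a functional assay on MCF7 cells (Homo sapiens) for cytotoxicity, read by sulforhodamine B assay, with a stated time of 48 h; a higher number here means a weaker inhibitor of growth, a lower number a stronger inhibitor of growth: compound 1 `CN(C)CN1C(=O)C(=O)c2c(Br)cccc21` gives 57600 nM; compound 2 `O=C1C(=O)N(CN2CCCCC2)c2cccc(Br)c21` gives 31500 nM; compound 3 `CCN(CC)CN1C(=O)C(=O)c2c(Br)cccc21` gives 20200 nM.

Among these three, compound 1 has the highest number, so it is the weakest inhibitor of growth. Its nearest neighbour is compound 2, reached by a 1.8-fold lower number from compound 1 to compound 2 (0.26 log units; within the scatter), a step within the scatter. The step to compound 3, a 2.9-fold lower number from compound 1 to compound 3 (0.46 log units; beyond the scatter), is the only one of the three that goes beyond the scatter. The step between the other two, a 1.6-fold lower number from compound 2 to compound 3 (0.19 log units; within the scatter), again lies within the scatter. All three steps change only the amine on the saturated chain carbon.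

Compound 4 `CN(C)CN1C(=O)C(=O)c2ccccc21` differs from compound 1 in another way: hydrogen in place of bromo on an aromatic carbon, on an aromatic carbon of the six-membered aromatic ring of carbon only, part of a fused system of two rings. Among the measured compounds shown here, none of the measured steps touches this part of the core, so no measured step bears on the change directly. With no guidance either way, compound 4 is expected to sit close to compound 1, at most a small change in either direction, so the step of a 1.3-fold higher number from compound 1 to compound 4 (0.11 log units; within the scatter) is estimated to fall within or just beyond the scatter. Compound 4 is therefore estimated at 75000 nM in this assay, with a range from 25000 nM to 220000 nM.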

Compound 4, concentration for 50% growth inhibition: 40500 nM
Compound 4: the middle estimate sits 1.9-fold (0.27 log units) above what was measured; the range from low to high includes it.
By their numbers in this assay, from the lowest: compounds 3, 2, 4 and 1 (each within the scatter of the next, the first and the last beyond it).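

In this assay, hydrogen in place of bromo on an aromatic carbon gives a 1.4-fold lower number from compound 1 to compound 4 (0.15 log units; within the scatter), so this change at this position cannot be told apart from the usual scatter. Among the compounds shown here, this is the first measured step that touches the aromatic part of the core rather than the amine, and it shows that, with dimethylamino kept in place, growth inhibition at this level does not depend on the bromo. Nothing measured here offers an explanation for this result.

On these data alone, it remains open whether a different group on this aromatic carbon, such as chloro, methoxy or nitrile, would give a step beyond the scatter. Also open, as far as these compounds go, is whether hydrogen in place of bromo would give a similarly small step with diethylamino or piperidin-1-yl as the amine.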